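From Hydrogen Back to Alkyl on the Aromatic Nitrogen

The compounds below may be only part of what the source reports. "The series", "measured", "known", "first", "only" and "open" are said of these compounds alone.

Compound 2 `NC1=N[C@@H](CNc2cccc(Cl)c2)CO1` gives 58% in a functional assay on HEK293 cells for agonist activity at trace amine-associated receptor 1 (Homo sapiens), read by cAMP accumulation, with a stated time of 30 min (on this read-out higher numbers stand for larger maximal responses and lower numbers for smaller maximal responses), the lower of the two numbers measured. Compound 1 `CN(C[C@H]1COC(N)=N1)c1cccc(Cl)c1` gives 84%. Compound 3 `CCN(C[C@H]1COC(N)=N1)c1cccc(Cl)c1` differs from compound 2 by ethyl in place of hydrogen on a nitrogen on an aromatic ring. Going by the values given here, the one measured step bears directly on this change: a number 26 percentage points lower from compound 1 to compound 2 (beyond the scatter). Compound 3 carries an alkyl group on that same nitrogen, as compound 1 does, so the expected step in this assay runs the other way, upward and beyond the scatter. Compound 3 is therefore estimated at 78%, within 60% to 92%, which means an expected step of a number 20 percentage points higher from compound 2 to compound 3 (beyond the scatter).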

Compound 3, largest response reached (Emax), in percent of the reference or control that the assay uses: 85%
For compound 3 the middle estimate is 7 percentage points below the measured one; the range from low to high includes it.
By their numbers in this assay, from the lowest: compound 2; then compounds 1 and 3 (each within the scatter of the next).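

The higher response now appears with a second alkyl group on this nitrogen: this assay shows a number 27 percentage points higher from compound 2 to compound 3 (beyond the scatter) for ethyl in place of hydrogen. Going from methyl to ethyl adds a carbon but gives a number 1 percentage points higher from compound 1 to compound 3 (within the scatter), so these two alkyl groups cannot be told apart on this read-out. Nothing available explains why either alkyl group differs from hydrogen here.

Going by these compounds, whether a longer chain such as propyl, or a branched group such as isopropyl, on the same nitrogen keeps this response remains open.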